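Hydrazinone series: capping the side-chain alcohol

A few compounds are considered here, and "the series" means these few. Any claim that something is new, unique, unknown or untested is made for them only; others in the source may bear on it.

Measured so far:
compound 1 `O=c1ccc(CCCO)nn1Cc1ccccc1` — > 100000 nM
compound 2 `Cn1nc(CCO[Si](c2ccccc2)(c2ccccc2)C(C)(C)C)ccc1=O` — 47000 nM
compound 3 `Cn1nc(CCCO[Si](c2ccccc2)(c2ccccc2)C(C)(C)C)ccc1=O` — > 100000 nM

In a functional assay on aorta (Rattus norvegicus) (on this read-out lower numbers stand for stronger inhibition and higher numbers for weaker inhibition), compound 1 gives only a limit, > 100000 nM. Compound 4 `O=c1ccc(CCOCc2ccccc2)nn1Cc1ccccc1` differs from it by benzyloxy in place of hydroxymethyl on a saturated chain carbon, two bonds along the chain from an aromatic carbon. Going by the values given here, no measured step concerns this change; the single measured step, an at least 2.1-fold higher number from compound 2 to compound 3 (0.32 log units; beyond the scatter), concerns chain length and adds nothing here, and the limit of > 100000 nM in this assay, at which 2 of the 3 values shown sit, leaves the size of any step from compound 1 unknown. Among the compounds with values here, compound 2 is the only compound with a capped alcohol that reaches a number, 47000 nM. A step of an at least 1.6-fold lower number from compound 1 to compound 4 (0.22 log units; that floor lies within the scatter) is therefore expected, though poorly defined. Compound 4 is estimated at 60000 nM, in the range 15000 nM to 300000 nM.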

Compound 4, half-maximal inhibitory concentration: 32300 nM
Compound 4: middle estimate off by 1.9-fold (0.27 log units), on the high side; measured number inside the range.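

In this assay, going by these compounds alone, benzyloxy in place of hydroxymethyl on a saturated chain carbon gives an at least 3.0-fold lower number from compound 1 to compound 4 (0.49 log units; beyond the scatter), the first readable step for a change at this position on the shared core. With the hydrogen-bond donor gone and a carbon-only aromatic ring added, this end of the chain now gives a number. The step is only a floor, because compound 1 carries a limit and not a number: the limit of > 100000 nM in this assay, at which 2 of the 4 values shown sit.

As far as these compounds go, whether the step follows from losing the donor or from adding the ring stays open. Also open, from the compounds shown here alone, is how an amine, a carboxylic acid or a methoxy group would read here.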